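One stereocentre changed: compound 3 to compound 4

A few compounds are considered here, and "the series" means these few. Any claim that something is new, unique, unknown or untested is made for them only; others in the source may bear on it.

In a functional assay on MCF7 cells (Homo sapiens) for cytotoxicity, read by MTT assay (a lower number here means a stronger inhibitor, a higher number a weaker inhibitor), the series offers little to work from. Compound 1 (`COC(=O)C[C@H]1C[C@H](O)[C@@H](C)[C@@H](c2ccc(C)cc2)N1`) gives "not active" (no number reported), with no number reported. Compound 2 (`COC(=O)C[C@H]1C[C@H](O)[C@@H](C)[C@@H](c2ccc(C(C)C)cc2)N1`) gives 17100 nM, and compound 3 (`COC(=O)C[C@H]1C[C@@H](O)[C@@H](C)[C@@H](c2ccc(OC)cc2)N1`) gives 10400 nM. These two numbers lie within the usual scatter of each other, so compound 3 stands level with compound 2.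

Compound 4 (`COC(=O)C[C@H]1C[C@H](O)[C@@H](C)[C@@H](c2ccc(OC)cc2)N1`) has the same atoms and bonds as compound 3 and differs only in configuration as drawn: the two compounds have the same atoms and bonds and differ only in configuration as drawn: 1 of 4 stereo elements differ; a stereocentre at a saturated ring carbon is drawn R in compound 3 and S in compound 4. A stereocentre at a saturated ring carbon is drawn R in compound 3 and S in compound 4.

Within the data shown here, no measured pair isolates a change of configuration, so the size of this step in this assay has no direct precedent. The working expectation is no step beyond the scatter, starting from compound 3 at 10400 nM. The range is kept wide, and a result without a number remains possible, as seen for compound 1 at "not active" (no number reported). The expected change is a 1.3-fold higher number from compound 3 to compound 4 (0.13 log units; within the scatter). For compound 4 the estimated value is 14000 nM, with an expected range from 6000 nM to 40000 nM.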

Compound 4, half-maximal inhibitory concentration: 5100 nM
The estimate for compound 4 lay 2.7-fold (0.44 log units) above the measured number; measured number below the stated range.
By their numbers in this assay, from the lowest: compound 4; then compounds 3 and 2 (each within the scatter of the next).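

In this assay, among these compounds, drawing this saturated ring stereocentre as S rather than R gives a 2.0-fold lower number from compound 3 to compound 4 (0.31 log units; beyond the scatter), the first evidence that configuration alone can move the read-out beyond the scatter. The step can be assigned to this stereocentre and to no other structural change: the fact that compounds 3 and 4 differ only in the configuration as drawn

With that configuration held, methoxy in place of isopropyl on an aromatic carbon gives a 3.4-fold lower number from compound 2 to compound 4 (0.53 log units; beyond the scatter), a substituent step that the level reading of compound 2 and compound 3 could not show, as that pair combines this change with the change in configuration.

From the compounds shown here alone, whether the same configuration step holds with an aromatic substituent other than methoxy remains open, as does the effect of changing any of the other three stereo elements. Also open, going by these compounds, is how the read-out responds when the methyl ester is replaced by a carboxylic acid or an amide, or when the aromatic substituent is an amine or a longer chain.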